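The source may hold more compounds than are shown below. What is called first, only, known or untested is meant among the compounds shown, and "the series" means these compounds.

Measured so far in a functional assay on L1210 cells (Mus musculus) for inhibition; a higher number here means a weaker inhibitor, a lower number a stronger inhibitor:
- compound 1 `Nc1nc(O)c2ncn(C/C=C/CO)c2n1` gives 200000 nM
- compound 2 `Cc1cn(C/C=C\CCl)c(=O)[nH]c1=O` gives 46000 nM

Compound 2 holds the lower of the two numbers, and compound 1 sits higher, beyond the scatter. Compound 3 `Cc1cn(C/C=C\CO)c(=O)[nH]c1=O` is not yet measured. Compared with compound 2, compound 3 shows (hydroxy in place of chloro on a saturated chain carbon bound to a double-bonded chain carbon), hydroxy in place of chloro on a saturated chain carbon bound to a double-bonded chain carbon. Compound 1 also carries hydroxy on its chain and reads 200000 nM, so a move towards a higher number, beyond the scatter, is expected. The expected step is a 3.3-fold higher number from compound 2 to compound 3 (0.51 log units; beyond the scatter). For compound 3 the estimated value is 150000 nM, with an expected range of 50000 nM to 450000 nM.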

Compound 3, half-maximal inhibitory concentration: > 1000000 nM
Compound 3 was reported as a limit (the forecaster's own chance of this, stated with the estimate: 30%); at least 6.6-fold (0.82 log units) between middle value and limit.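

In this assay, this saturated chain carbon bound to a double-bonded chain carbon proves sensitive to a single-atom exchange: hydroxy in place of chloro gives an at least 21-fold higher number from compound 2 to compound 3 (1.33 log units; beyond the scatter). Compound 3 stands at a limit of the assay, > 1000000 nM, so the step has a lower bound only. Of this pair, only compound 2 gives a number, 46000 nM.

Open, on these data alone, is whether chloro is specifically required, or whether bromo, methoxy or an amine on the same carbon would also give a measurable number. Also open, as far as these compounds go, is whether chloro on the chain of the core of compound 1 would give a similar step.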